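The compounds below may be only part of what the source reports. "The series", "measured", "known", "first", "only" and "open" are said of these compounds alone.

In an ADME assay on MRC5 cells (Homo sapiens) for cytotoxicity, read by fluorescence, with a stated time of 72 h (on this read-out lower numbers stand for stronger inhibition and higher numbers for weaker inhibition), compound 1 `O=[N+]([O-])c1cnc2n1C[C@@H](COc1ccc(OC(F)(F)F)cc1)O2` gives > 64000 nM, which is a limit of the assay and not a number. Among the measured compounds shown here, compound 2 `O=[N+]([O-])c1cn2c(n1)OC(COc1ccc(-c3ccc(C(F)(F)F)cc3)cn1)C2` gives 45000 nM, the only actual number so far, so it has no measured neighbour to be ranked against. Compound 3 `O=[N+]([O-])c1cn2c(n1)OC(COc1ccc(-c3ccc(OC(F)(F)F)cc3)cn1)C2` carries trifluoromethoxy in place of trifluoromethyl on an aromatic carbon, para to a large group: trifluoromethoxy in place of trifluoromethyl on an aromatic carbon. For the measured compounds named here, no measured step shows what this swap does, so no shift beyond the usual scatter is expected in this assay. The expected step is no change at the digits printed from compound 2 to compound 3 (within the scatter). For compound 3, the estimated value is 45000 nM, within an expected range of 22000 nM to 64000 nM.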

Compound 3, half-maximal inhibitory concentration: 47000 nM
The estimate for compound 3 lay 1.0-fold (0.02 log units) below the measured number, within the range that was stated.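

In this assay, putting trifluoromethoxy in place of trifluoromethyl on an aromatic carbon, para to a large group, gives a 1.0-fold higher number from compound 2 to compound 3 (0.02 log units; within the scatter). Among the compounds shown here, this is the first comparison here between two actual numbers, and it shows that the added oxygen, with its one hydrogen-bond acceptor, does not separate the two compounds in this assay. Nothing measured here bears on why.

Going by these compounds, whether an amine or a carboxylic acid at this position would shift the number stays open. A single pair also cannot show whether this swap would behave alike on another core.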